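A few compounds are considered here, and "the series" means these few. Any claim that something is new, unique, unknown or untested is made for them only; others in the source may bear on it.

In a functional assay on brain (Rattus norvegicus, strain Wistar) for inhibition (on this read-out higher numbers stand for weaker inhibition and lower numbers for stronger inhibition), compound 1 (`CCCCCCCCCCOc1ccc(-c2c(C)[nH]c(=O)n2C)cc1`) gives 6900 nM and compound 2 (`CCCCCCCCOc1ccc(-c2c(C)[nH]c(=O)n2C2CCCCC2)cc1`) stands at 8500 nM on the same read-out, so these two values lie within the scatter of each other. Among the measured compounds shown here, the two compounds differ in more than one place, and no measured step isolates a single change. Compound 3 (`CCCCCCCCCCOc1ccc(-c2c(C)[nH]c(=O)n2C2CCCCC2)cc1`) differs from compound 2 by one change: ethyl in place of hydrogen on a saturated chain carbon, eight bonds along the chain from an oxygen on an aromatic ring. For the measured compounds named here, with no measured step for this change, the expectation in this assay is for no shift beyond the scatter in either direction. The expected move, a 1.1-fold lower number from compound 2 to compound 3 (0.05 log units; within the scatter) on this estimate, is small. The estimate for compound 3 is 7500 nM with an expected range of 3000 nM to 18000 nM on this read-out.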

Compound 3, half-maximal inhibitory concentration: 10500 nM
Compound 3: middle estimate off by 1.4-fold (0.15 log units), on the low side; the range from low to high includes it.
By their numbers in this assay, from the lowest: compounds 1, 2 and 3 (each within the scatter of the next).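

In this assay, the chain extension gives a 1.2-fold higher number from compound 2 to compound 3 (0.09 log units; within the scatter) and so shows no shift at this position: ethyl in place of hydrogen on a saturated chain carbon, eight bonds along the chain from an oxygen on an aromatic ring, leaves the number within the scatter. With the chain the same, cyclohexyl in place of methyl on an aromatic nitrogen gives a 1.5-fold higher number from compound 1 to compound 3 (0.18 log units; within the scatter) and also stays within the scatter, the first single change read at that nitrogen. Nothing available bears on why these values lie so close.

Going by these compounds, whether any group at either place moves the number beyond the scatter remains open. A longer chain, or an amine or a carboxylic acid in place of that ethyl, would test the chain position, and a phenyl in place of the cyclohexyl would test the nitrogen.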